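A few compounds are considered here, and "the series" means these few. Any claim that something is new, unique, unknown or untested is made for them only; others in the source may bear on it.

Measured compounds:
compound 1 `Fc1ccc(Nc2cc3[nH]c(Nc4ccc(N5CCNCC5)cn4)nc3cn2)cc1C(F)(F)F`: 180000 nM
compound 2 `Fc1ccc(Nc2cc3[nH]c(Nc4ccc(N5CCNCC5)cn4)nc3cn2)cc1F`: < 5000 nM, a limit
compound 3 `O=C(c1ccnc(Nc2nc3cnc(Nc4ccc(F)c(C(F)(F)F)c4)cc3[nH]2)c1)N1CCN(C2CC2)CC1`: < 5000 nM, a limit

In a physicochemical assay for solubility, read by HPLC, using the shake flask method, in phosphate buffer, measured as kinetic solubility, with a stated time of 20 h, at pH 6.5 (on this read-out higher numbers stand for higher solubility and lower numbers for lower solubility), compound 1 gives 180000 nM. For compound 2 this assay reports only a limit, < 5000 nM. For compound 3 it likewise reports only a limit, < 5000 nM. The difference between the core of compound 1 and the core of compound 3 is not broken down here. The change from compound 1 to compound 2 is fluoro in place of trifluoromethyl on an aromatic carbon; it gave an at least 36-fold lower number from compound 1 to compound 2 (1.55 log units; beyond the scatter). Compound 4 `O=C(c1ccnc(Nc2nc3cnc(Nc4ccc(F)c(F)c4)cc3[nH]2)c1)N1CCN(C2CC2)CC1`, not yet measured, carries the same change on the core of compound 3: fluoro in place of trifluoromethyl on an aromatic carbon. Compound 3 already sits at the limit of < 5000 nM in this assay, at which 2 of the 3 values shown sit, so the step is expected to run the same way, a step that the limit leaves unreadable from compound 3 to compound 4, though the assay may again report only a limit. Compound 4 is expected at 1500 nM, between 300 nM and 5000 nM.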

Compound 4, solubility: < 5000 nM
Compound 4: only a limit was reported; the forecaster's own chance of this, stated with the estimate: 85%; the middle value is on the limit's open side.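

Compound 3 and compound 4 are both reported only as limits in this assay, and no step between them can be read: the limit of < 5000 nM in this assay, at which 3 of the 4 values shown sit.

Still open, from the compounds shown here alone, is whether fluoro in place of trifluoromethyl changes solubility on the core of compound 3 as it does on the core of compound 1.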